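The source may hold more compounds than are shown below. What is called first, only, known or untested is meant among the compounds shown, and "the series" means these compounds.

For the measured compounds named here, in a functional assay on L1210 cells (Mus musculus) for inhibition (on this read-out lower numbers stand for stronger inhibition and higher numbers for weaker inhibition), compound 1 (`CCOC(=O)Nc1cc2c(c(N)n1)N=C(c1ccccc1)CN2`) gives 4.7 nM and holds the lowest of the two numbers so far. Compound 2 (`Nc1nc(NC(=O)OC2CCCCC2)cc2c1N=C(c1ccccc1)CN2`) gives 230 nM on the same read-out. Going by the values given here, the only measured step, a 49-fold higher number from compound 1 to compound 2 (1.69 log units; beyond the scatter) for cyclohexyl in place of ethyl on an oxygen next to a carbonyl group, is large.

Compound 3 (`CCOC(=O)Nc1cc2c(c(NC(C)=O)n1)N=C(c1ccccc1)CN2`) keeps that ethyl group and changes elsewhere: amino to acetamido, with acetyl in place of hydrogen on a nitrogen on an aromatic ring. Among the compounds with values here, no measured step touches this nitrogen, so a 49-fold higher number from compound 1 to compound 2 (1.69 log units; beyond the scatter) bears on it only indirectly, as the sole sign that one change on the shared core can move the number by a large amount. With compound 1 at 4.7 nM at the low end of the series, a clear step to a higher number is expected in this assay rather than none, and its size remains uncertain. The expected move is a 32-fold higher number from compound 1 to compound 3 (1.50 log units; beyond the scatter) on this estimate. For compound 3 the estimated value is 150 nM with an expected range from 25 nM to 900 nM on this read-out.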

Compound 3, half-maximal inhibitory concentration: 8.6 nM
The estimate for compound 3 lay 17-fold (1.24 log units) above the measured number, outside the stated range (below it).
By their numbers in this assay, from the lowest: compounds 1 and 3 (each within the scatter of the next); then compound 2.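

Working notes on the nitrogen on an aromatic ring: in this assay acetyl in place of hydrogen gives a 1.8-fold higher number from compound 1 to compound 3 (0.26 log units; within the scatter) and so adds no step beyond the scatter on the shared core. The earlier step of a 49-fold higher number from compound 1 to compound 2 (1.69 log units; beyond the scatter) came from cyclohexyl in place of ethyl on the oxygen, and this second change shows that a large step does not follow from every change on the core, though only these two changes can be set against each other. Nothing measured here explains why acetyl on this nitrogen leaves the number within the scatter of compound 1.

From the compounds shown here alone, whether the result extends past acetyl stays open: a benzoyl group or a longer acyl chain such as butanoyl on this nitrogen, or a plain methyl group in place of the acetyl group, could read differently from compound 3. Going by these compounds, it is also open whether acetyl in place of hydrogen on this nitrogen reads the same when the cyclohexyl group of compound 2 stands in place of the ethyl group.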